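From methoxy to methylsulfanyl in a small inhibitor series

The source may report more compounds than this note shows. Statements on the series, on what has been measured and on what is new or still open speak of the compounds shown alone.

In a functional assay for inhibition, with Rattus norvegicus as the target (a lower number here means a stronger inhibitor, a higher number a weaker inhibitor), compound 1 (`CC(/N=c1\c(O)c(O)\c1=N/c1cccnc1)C(C)(C)C`) gives 1950 nM as its reading, and compound 2 (`CC(/N=c1\c(O)c(O)\c1=N/c1cccc2cccnc12)C(C)(C)C`) gives 8100 nM as its reading. Compound 3 (`COc1ccc(Nc2c(NC(C)C(C)(C)C)c(=O)c2=O)cc1`) gives 2400 nM as its reading, which sits within the usual scatter of compound 1 and well under the number for compound 2.

Compound 4 (`CSc1ccc(Nc2c(NC(C)C(C)(C)C)c(=O)c2=O)cc1`) keeps all of compound 3 except one group, with methylsulfanyl in place of methoxy on an aromatic carbon. Among the measured compounds shown here, no two measured compounds here differ in one place only, so the data offer no direct guide to the size of such a swap. With so little to go on, the cautious expectation is no change beyond the scatter. The expected move a 1.1-fold lower number from compound 3 to compound 4 (0.04 log units; within the scatter) is small and stays inside the scatter. The estimated value for compound 4 is 2200 nM within a range running from 900 nM at the low end to 5500 nM at the high end.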

Compound 4, half-maximal inhibitory concentration: > 30000 nM
Compound 4 ended at the assay's limit; the forecaster's own chance of this, stated with the estimate: 3%; at least 13-fold (1.13 log units) between middle value and limit.
By their numbers in this assay, from the lowest: compounds 1 and 3 (each within the scatter of the next); then compound 2. At a limit, above all of these: compound 4.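

In this assay, the change of methoxy to methylsulfanyl gives an at least 12-fold higher number from compound 3 to compound 4 (1.09 log units; beyond the scatter), a large step well beyond the scatter. Among the compounds shown here, compound 4 stands at a limit of the assay, not at a number: the limit of > 30000 nM in this assay, at which 1 of the 4 values shown sits. This is the first direct view of this position, on an aromatic carbon para to a large group, and it shows that two groups with the same counts of heavy atoms, hydrogen-bond donors and hydrogen-bond acceptors can still read very differently.

One pair cannot tell whether methoxy is unusually well suited to this position or methylsulfanyl is unusually poor. As far as these compounds go, a hydroxyl, an amine or a longer chain such as ethoxy at the same place could help to separate those two readings, and how any of them would fare remains open.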